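Swapping the ketone aryl group on a chalcone-like scaffold

A few compounds are considered here, and "the series" means these few. Any claim that something is new, unique, unknown or untested is made for them only; others in the source may bear on it.

Of the compounds shown here, two built on a shared core have been tested in an ADME assay on HEK293 cells (Homo sapiens) for antiproliferative activity, read by MTT assay, with a stated time of 24 h; on this read-out higher numbers stand for weaker inhibition and lower numbers for stronger inhibition. Compound 1 `COc1ccc(-c2cc(/C=C/C(=O)c3ccc(Cl)cc3)nc3cc(-c4ccccc4)nn23)cc1OC` gives 44100 nM in this assay. Compound 2 `COc1ccc(C(=O)/C=C/c2cc(-c3cc(OC)c(OC)c(OC)c3)n3nc(-c4ccccc4)cc3n2)cc1OC` gives 81700 nM in this assay; this is the higher of the two numbers, but the gap to compound 1 lies within the usual scatter of repeated measurements, so the two cannot be told apart on these data.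

Compound 3 `COc1cc(-c2cc(/C=C/C(=O)c3ccc(Cl)cc3)nc3cc(-c4ccccc4)nn23)cc(OC)c1OC` has not yet been measured in this assay. It differs from compound 2 in a single place: 4-chlorophenyl in place of 3,4-dimethoxyphenyl on a carbonyl carbon. The same 4-chlorophenyl group on the carbonyl carbon is already present in compound 1, whose number in this assay sits within the scatter of that of compound 2. Among the compounds with values here, with no step between measured compounds available, the change from compound 2 to compound 3 is expected to bring a shift of a 1.5-fold lower number from compound 2 to compound 3 (0.17 log units; within the scatter), that is, nothing clearly beyond the scatter, with a slight lean toward a lower number. Compound 3 is therefore expected to give about 55000 nM in this assay, with a likely range from 20000 nM to 150000 nM.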

Compound 3, half-maximal inhibitory concentration: >= 100000 nM
Compound 3 gave a limit, no number (the forecaster's own chance of this, stated with the estimate: 10%); at least 1.8-fold (0.25 log units) between middle value and limit.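

In this assay, compound 3 gives a limit and not a number: the limit of >= 100000 nM in this assay, at which 1 of the 3 values shown sits. Within the data shown here, on the carbonyl carbon, 4-chlorophenyl in place of 3,4-dimethoxyphenyl brings an at least 1.2-fold higher number from compound 2 to compound 3 (0.08 log units; that floor lies within the scatter), so this is the first direct reading of the swap, and its floor alone does not show a clear effect, though it also gives no sign of stronger inhibition. Among these compounds, the second step gives the clearer signal: methoxy in place of hydrogen on an aromatic carbon, with 4-chlorophenyl kept on the carbonyl carbon, brings an at least 2.2-fold higher number from compound 1 to compound 3 (0.35 log units; beyond the scatter), the only new step whose floor already clears the scatter, and it shows that this small addition away from the carbonyl carbon goes with weaker inhibition.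

From the compounds shown here alone, both steps are floors, so how far either one really reaches stays open. Going by these compounds, it also stays open whether a quite different group on the carbonyl carbon, such as an amine or a carboxylic acid in place of these aryl groups, would move the number in either direction.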